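From compound 3 to compound 4: an expected step

The source may hold more compounds than are shown below. What is called first, only, known or untested is meant among the compounds shown, and "the series" means these compounds.

Among the measured compounds shown here, in a physicochemical assay for lipophilicity, at pH 7.4 (on this read-out higher numbers stand for higher lipophilicity and lower numbers for lower lipophilicity), compound 1 `Cc1cc(C(N)=O)nn1Cc1cc(Cl)ccc1OCc1ccccc1` gives 3.7 as the only number. Compound 2 `Cc1cc(C(=O)Nc2ccccc2)nn1Cc1cc(Cl)ccc1OCc1ccccc1` is reported only as a limit at > 3.7 on this read-out. Compound 3 `Cc1cc(C(=O)NCc2ccccn2)nn1Cc1cc(Cl)ccc1OCc1ccccc1` likewise gives only a limit, > 3.7 on the same read-out. That leaves compound 3 at the limit of > 3.7 in this assay, at which 2 of the 3 values shown sit, with no number of its own.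

Compound 4 `Cc1cc(NC(=O)C2CCCC2)nn1Cc1cc(Cl)ccc1OCc1ccccc1` is not yet measured and differs from compound 3 by (cyclopentylcarbonyl)amino in place of ((pyridin-2-yl)methyl)carbamoyl on an aromatic carbon in one place: (cyclopentylcarbonyl)amino in place of ((pyridin-2-yl)methyl)carbamoyl on an aromatic carbon of a five-membered aromatic ring with 2 nitrogen.

For the measured compounds named here, no measured step covers this exchange. The nearest are two steps (a number no lower from compound 1 to compound 2 (the limit leaves the size open)) and (a number no lower from compound 1 to compound 3 (the limit leaves the size open)) that give a direction without a size, while a third (a step that the two limits leave unreadable from compound 2 to compound 3) gives neither. The upward reading in this assay rests only on compound 1 at 3.7 and the direction of (a number no lower from compound 1 to compound 3 (the limit leaves the size open)) in the series. On that basis the expected step is modest and upward, estimated as a step that the limit leaves unreadable from compound 3 to compound 4 with wide uncertainty. For compound 4 the estimate is 4.2 within an expected range from 3.6 to 4.8 and a report as a limit alone is likely.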

Compound 4, distribution coefficient: 3.5
Beside the measured number, compound 4's estimate is 0.70 log units above it; measured number below the stated range.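

In this assay, among the compounds shown here, compound 4 is the only compound other than compound 1 to give a number rather than a limit, so a ring-bearing amide-type group on this aromatic carbon does not by itself end at the limit that holds for the others: the limit of > 3.7 in this assay, at which 2 of the 4 values shown sit. Against the two compounds reported only as limits, the exchange to (cyclopentylcarbonyl)amino reads as a number at least 0.20 log units lower from compound 3 to compound 4 (that floor lies within the scatter) and as a number at least 0.20 log units lower from compound 2 to compound 4 (that floor lies within the scatter). Against the plain carbamoyl it reads as a number 0.20 log units lower from compound 1 to compound 4 (within the scatter), so the two stand level on this read-out, and the upward direction seen with phenyl and (pyridin-2-yl)methyl on the amide nitrogen does not carry over to this group.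

On these data alone, the steps that join only limits cannot be read, so the true size of any difference among those compounds stays unknown. The exchange also swaps the amide orientation and the end group together, so the compounds shown do not separate the two, and how a cyclopentyl on the carbamoyl nitrogen, a carboxylic acid or a simple amine would read at this place remains open.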